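The compounds below may be only part of what the source reports. "The series", "measured", "known", "first", "only" and "open" are said of these compounds alone.

Compound 1 `C=CC1=C(C(=O)NCCCCC)C(c2ccc(Cl)c(Cl)c2)OC1` in a functional assay on QGY7701 cells (Homo sapiens) for cytotoxicity, read by MTT assay, with a stated time of 24 h; a lower number here means a stronger inhibitor, a higher number a weaker inhibitor: > 100000 nM
Compound 2 `C=CC1=C(C(=O)NC(C)(C)C)C(c2ccc(Cl)c(Cl)c2)OC1` in this assay: > 100000 nM

Compound 1 and compound 2 share one core and differ only in the group on the amide-type nitrogen, pentyl in the first and tert-butyl in the second. In this assay compound 1 gives > 100000 nM, which is a limit of the assay and not a number. In this assay compound 2 gives > 100000 nM, again a limit and not a number. The step that the two limits leave unreadable from compound 1 to compound 2 cannot be read, since both values sit at the limit of > 100000 nM in this assay, at which 2 of the 2 values shown sit. Compound 2 thus stands at the limit of this assay, without a number of its own and without a readable step to any neighbour.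

Compound 3 `C=CC1=C(C(=O)Nc2ccccc2OC)C(c2ccc(Cl)c(Cl)c2)OC1` carries the change (2-methoxyphenyl in place of tert-butyl on an amide-type nitrogen). The only measured step on the same nitrogen, a step that the two limits leave unreadable from compound 1 to compound 2, gives no size, so nothing shown points to a move in either direction. The step that the limit leaves unreadable from compound 2 to compound 3 is expected to stay within the scatter. For compound 3 the estimate in this assay is 150000 nM, with the value most likely reported again only as a limit.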

Compound 3, half-maximal inhibitory concentration: > 100000 nM
Compound 3 gave a limit, no number; the forecaster's own chance of this, stated with the estimate: 75%; the middle value is on the limit's open side.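

In this assay compound 3 gives > 100000 nM, a limit of the assay and not a number. The steps to compound 3 from compound 1 and from compound 2 therefore cannot be read: the limit of > 100000 nM in this assay, at which 3 of the 3 values shown sit. The compounds shown leave open how pentyl, tert-butyl and 2-methoxyphenyl on the amide-type nitrogen compare, since none of the three has a number of its own.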